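The source may hold more compounds than are shown below. What is called first, only, known or untested is meant among the compounds shown, and "the series" means these compounds.

Working notes on the series. In a functional assay on cells (T-cell, Homo sapiens) for inhibition (on this read-out higher numbers stand for weaker inhibition and lower numbers for stronger inhibition), compound 1 `COc1ccc(-c2cnc3nc(N)nc(N4CCN(c5ccc(F)cc5)CC4)c3n2)cc1OC` gives 100 nM, while compound 2 `COc1ccc(-c2cnc3nc(N)nc(NCc4cccs4)c3n2)cc1OC` gives 4100 nM. Among the measured compounds shown here, compound 1 thus stands at the lower of the two numbers, and its gap to compound 2 lies well beyond the usual scatter; the two compounds differ in more than one place, so no single step is defined between them.

Compound 3 `COc1ccc(-c2cnc3nc(N)nc(N4CCN(c5ccccc5)CC4)c3n2)cc1OC` has not yet been measured in this assay. It differs from compound 1 in a single place: hydrogen in place of fluoro on an aromatic carbon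

The measured pair gives no direct guidance on this change. The step from compound 1 to compound 3 is expected to be small, a 1.3-fold higher number from compound 1 to compound 3 (0.11 log units; within the scatter), lying within the scatter rather than beyond it, with no clear direction. Compound 3 is therefore expected to give about 130 nM in this assay, with a range from 50 nM to 350 nM.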

Compound 3, half-maximal inhibitory concentration: 400 nM
Compound 3: the middle estimate sits 3.1-fold (0.49 log units) below what was measured; the measured number lies above the stated range.
By their numbers in this assay, from the lowest: compound 1; then compound 3; then compound 2.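

Among the compounds shown here, this is the first single-place step, and it shows that the aromatic carbon para to a large group is sensitive to what it carries. In this assay, the change from 4-fluorophenyl to phenyl gives a 4.0-fold higher number from compound 1 to compound 3 (0.60 log units; beyond the scatter) and is modest in size, so within this pair the fluoro goes with the stronger inhibition. Nothing at hand accounts for this step.

The compounds shown leave open whether the gain is specific to fluoro or would also appear with chloro, methyl, methoxy or an amine at the same place. For the compounds shown here, they also leave open whether the step holds on other versions of the shared core, since only one pair defines it so far.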